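Anilide series at the dopamine receptor: chloro to trifluoromethoxy

The source may report more compounds than this note shows. Statements on the series, on what has been measured and on what is new or still open speak of the compounds shown alone.

Measured so far in a functional assay on HEK293 cells for agonist activity at D(4) dopamine receptor (Homo sapiens), read by FLIPR; on this read-out higher numbers stand for an effect only at larger amounts of compound and lower numbers for an effect already at smaller amounts:
compound 1 `O=C(CN1CCC(c2cccc[n+]2[O-])CC1)Nc1cccc(-c2ccccc2)c1` gives 360 nM
compound 2 `O=C(CN1CCC(c2cccc[n+]2[O-])CC1)Nc1cccc(Cl)c1` gives 62 nM

Compound 2 stands lowest of the two numbers. Within the data shown here, the single step, a 5.8-fold lower number from compound 1 to compound 2 (0.76 log units; beyond the scatter), is the only comparison at hand. Compound 3 `O=C(CN1CCC(c2cccc[n+]2[O-])CC1)Nc1cccc(OC(F)(F)F)c1` is not yet measured; it differs from compound 2 by trifluoromethoxy in place of chloro on an aromatic carbon. Among the measured compounds shown here, no measured step covers a trifluoromethoxy group, so that one step bears only loosely. Since compound 1 gives 360 nM and compound 2 gives 62 nM, compound 3 is expected to land between them, a modest rise of a 1.9-fold higher number from compound 2 to compound 3 (0.29 log units; within the scatter). Compound 3 is estimated at 120 nM, between 40 nM and 360 nM.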

Compound 3, half-maximal effective concentration: 135 nM
Estimate against measurement, compound 3: 1.1-fold (0.05 log units) below; the measured number falls inside the stated range.
By their numbers in this assay, from the lowest: compound 2; then compound 3; then compound 1.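

The step of a 2.2-fold higher number from compound 2 to compound 3 (0.34 log units; beyond the scatter) and the step of a 2.7-fold lower number from compound 1 to compound 3 (0.43 log units; beyond the scatter) set trifluoromethoxy apart from both chloro and phenyl in this assay on this aromatic carbon. With three groups at this place, the order runs chloro, trifluoromethoxy, phenyl, and each gap lies beyond the scatter. Nothing measured here bears on why the groups fall in this order.

Open, as far as these compounds go, is how a fluoro, a methoxy or a nitrile on the same carbon would compare with chloro. Also open, from the compounds shown here alone, is whether this order holds with an amine or a carboxylic acid there.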